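A few compounds are considered here, and "the series" means these few. Any claim that something is new, unique, unknown or untested is made for them only; others in the source may bear on it.

Two compounds on the shared core have numbers in a functional assay on BGC-823 cells (Homo sapiens) for antiproliferative activity, read by MTT assay, tested at 1 uM (a higher number here means a stronger effect of the compound at the concentration tested, a lower number a weaker effect), so far. Compound 1, `COc1cc(C2=NN(C(C)=O)C(c3ccc(F)c(F)c3)O2)cc(OC)c1OC`, gives 18.3% in this assay. Compound 2, `COc1cc(C(=O)N/N=C/c2ccc(C(F)(F)F)cc2)cc(OC)c1OC`, gives 47.4% in this assay. Compound 1 stands lowest of the two numbers; compound 2 sits higher by a gap beyond the usual scatter. The two compounds differ in more than one place, so that pair says nothing about any single change.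

Compound 3, `COc1cc(C2=NN(C(C)=O)C(c3ccc(Cl)c([N+](=O)[O-])c3)O2)cc(OC)c1OC`, is the next compound waiting for this assay. Relative to compound 1 it carries one change: 4-chloro-3-nitrophenyl in place of 3,4-difluorophenyl on a saturated ring carbon. Among the compounds with values here, no measured pair on this core isolates a change of this kind, so there is no precedent to lean on, and the only anchor is compound 1 with its 18.3% in this assay. The expected step is therefore a modest one, a number 6.7 percentage points higher from compound 1 to compound 3 (within the scatter), with the direction left open and quite possibly not beyond the usual scatter. Compound 3 is accordingly estimated to come out near 25% in this assay, somewhere between 8% and 45%.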

Compound 3, a percentage reported as inhibition, at one concentration (the size of the read-out at that concentration, not a potency): -2.3%
For compound 3 the middle estimate is 27.3 percentage points above the measured one; the measured number lies below the stated range.
By their numbers in this assay, from the lowest: compound 3; then compound 1; then compound 2.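

On the shared core, the saturated ring carbon bearing the aryl group proves sensitive: in this assay, 4-chloro-3-nitrophenyl in place of 3,4-difluorophenyl gives a number 20.6 percentage points lower from compound 1 to compound 3 (beyond the scatter), the first single-place step available in this series. The change leaves no inhibition at the concentration tested, with compound 3 at -2.3%, so the modest effect of compound 1 at 18.3% depends on the aryl group at this position and does not come from the rest of the core alone. The data shown offer no measurement that explains this loss.

The step replaces both fluorines and adds chlorine and nitro groups in one move, so the compounds shown leave open whether the loss follows the chloro group, the nitro group or their combination; a 4-chlorophenyl or 3-nitrophenyl group would separate these, while a 4-aminophenyl group would test a different kind of substituent at the same carbon. Also open, as far as these compounds go, is whether the acetyl group on the neighbouring ring atom tolerates change, for instance to a longer chain such as propionyl, and how that would combine with the aryl group.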